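Methyl for trifluoromethyl on the amide aryl ring

The source may report more compounds than this note shows. Statements on the series, on what has been measured and on what is new or still open speak of the compounds shown alone.

Compound 1 `NC(=O)c1c(NC(=O)c2ccc(C(F)(F)F)cc2)sc2c1CCN(Cc1c(Cl)cccc1Cl)C2` gives 8530 nM in a functional assay on MKN-74 cells (Homo sapiens) for antiproliferative activity, with a stated time of 24 h; a lower number here means a stronger inhibitor, a higher number a weaker inhibitor. Compound 2 `Cc1ccc(C(=O)Nc2sc3c(c2C(N)=O)CCN(Cc2c(Cl)cccc2Cl)C3)cc1` differs from compound 1 by methyl in place of trifluoromethyl on an aromatic carbon. In this assay compound 2 gives 12300 nM, which is a 1.4-fold higher number from compound 1 to compound 2 (0.16 log units; within the scatter). Compound 3 `NC(=O)c1c(NC(=O)c2ccc(C(F)(F)F)cc2)sc2c1CCN(C(=S)Nc1cc(C(F)(F)F)cc(C(F)(F)F)c1)C2` gives 13800 nM in this assay; the difference between the core of compound 3 and the core of compound 1 is not broken down here, and the two values lie within the scatter of each other. Compound 4 `Cc1ccc(C(=O)Nc2sc3c(c2C(N)=O)CCN(C(=S)Nc2cc(C(F)(F)F)cc(C(F)(F)F)c2)C3)cc1` is not yet measured; it differs from compound 3 by methyl in place of trifluoromethyl on an aromatic carbon, the same change as that from compound 1 to compound 2. Because a 1.4-fold higher number from compound 1 to compound 2 (0.16 log units; within the scatter), the step of a 1.3-fold higher number from compound 3 to compound 4 (0.12 log units; within the scatter) is expected, a flat move within the scatter. Compound 4 is thus estimated at 18000 nM in this assay, between 9000 nM and 40000 nM.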

Compound 4, half-maximal inhibitory concentration: 14900 nM
For compound 4 the middle estimate is 1.2-fold (0.08 log units) above the measured one; low and high end bracket the measured number.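

In this assay, methyl in place of trifluoromethyl on the amide aryl ring gives a 1.1-fold higher number from compound 3 to compound 4 (0.03 log units; within the scatter), a flat step on the second core. The steps on the two cores do not differ: the same change on two cores in this assay, a 1.4-fold higher number (0.16 log units; within the scatter) from compound 1 to compound 2 and a 1.1-fold higher number (0.03 log units; within the scatter) from compound 3 to compound 4, 1.3-fold (0.13 log units) apart, within the scatter of two such steps. This shows that the change stays flat on both cores shown, but with both steps inside the scatter it shows no real effect of the change on either core, and it cannot say whether a third core would behave alike.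

The compounds shown leave open whether another group at this place on the ring, such as an amine, a carboxylic acid or a longer chain, would move the number beyond the scatter. Also open, on these data alone, is how this change reads in any other read-out.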